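Solubility of amide variants: isobutyl to isopropyl

The source may hold more compounds than are shown below. What is called first, only, known or untested is meant among the compounds shown, and "the series" means these compounds.

Measured compounds:
Compound 1, `CNC(=O)c1cc(C(=O)NC2CCC2)cn(Cc2ccccc2)c1=O`: in a physicochemical assay for solubility (a lower number here means a less soluble compound, a higher number a more soluble compound), compound 1 gives 28 ug/mL.
Compound 2, `CNC(=O)c1cc(C(=O)NC2CCOCC2)cn(Cc2ccccc2)c1=O`: compound 2 gives a limit of the assay, >= 174 ug/mL.
Compound 3, `CNC(=O)c1cc(C(=O)NCC(C)C)cn(Cc2ccccc2)c1=O`: compound 3 gives 43 ug/mL.

Compound 3 has the highest of the two plain numbers, with compound 1 nearest: a 1.5-fold higher number from compound 1 to compound 3 (0.19 log units; within the scatter). Compound 2 sits at a limit, (the limit of >= 174 ug/mL in this assay, at which 1 of the 3 values shown sits).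

Compound 4, `CNC(=O)c1cc(C(=O)NC(C)C)cn(Cc2ccccc2)c1=O`, differs from compound 3 only on the amide-type nitrogen: isopropyl in place of isobutyl on an amide-type nitrogen. Within the data shown here, no measured step removes a single carbon from such a chain. The closest guide is a 1.5-fold higher number from compound 1 to compound 3 (0.19 log units; within the scatter), a swap of one small hydrocarbon group for another that stayed within the scatter, whereas an at least 4.0-fold lower number from compound 2 to compound 3 (0.60 log units; beyond the scatter) involved a ring with oxygen and does not resemble this change. A step within the scatter is therefore expected, a 1.2-fold higher number from compound 3 to compound 4 (0.07 log units; within the scatter), and compound 4 is estimated at 50 ug/mL, between 25 ug/mL and 100 ug/mL.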

Compound 4, solubility: >= 136 ug/mL
Compound 4 ended at the assay's limit (the forecaster's own chance of this, stated with the estimate: 5%); at least 2.7-fold (0.43 log units) between middle value and limit.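

At this amide-type nitrogen, a small change within the hydrocarbon groups can matter: in this assay, isopropyl in place of isobutyl gives an at least 3.1-fold higher number from compound 3 to compound 4 (0.50 log units; beyond the scatter). Isopropyl in place of cyclobutyl gives an at least 4.8-fold higher number from compound 1 to compound 4 (0.68 log units; beyond the scatter), so a group without a ring oxygen also clears the values of compound 1 and compound 3. The reading of compound 4 is a limit of the assay, not a number: the limit of >= 136 ug/mL in this assay, at which 1 of the 4 values shown sits.

As far as these compounds go, the step between compound 2 and compound 4 cannot be read, and the true value of compound 4 remains open. Also open, from the compounds shown here alone, is whether an ethyl group, a longer chain or an amine at this nitrogen would give a similar reading.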